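The source may hold more compounds than are shown below. What is called first, only, known or untested is meant among the compounds shown, and "the series" means these compounds.

Among the compounds with values here, compound 1 `CN(C)c1c(C(=O)NCc2ccc(F)cc2F)c(=O)n(O)c2ncccc12` gives 13000 nM in an ADME assay on HOS cells (Homo sapiens) for cytotoxicity, read by a luciferase reporter and ATP content (on this read-out higher numbers stand for lower toxicity in this test and lower numbers for higher toxicity in this test), the lowest of the three numbers measured so far. Compound 2 `O=C(NCc1ccc(F)cc1F)c1c(NC2CCCCCC2)c2cccnc2n(O)c1=O` gives 68000 nM in this assay, and compound 3 `O=C(NCc1ccc(F)cc1F)c1c(NCCCCc2ccccc2)c2cccnc2n(O)c1=O` gives 102000 nM in this assay. Two measured steps exchange the dimethylamino of compound 1 for another amino group on the same aromatic carbon: a 5.2-fold higher number from compound 1 to compound 2 (0.72 log units; beyond the scatter), and a 7.8-fold higher number from compound 1 to compound 3 (0.89 log units; beyond the scatter). Between the two replacement groups the difference is small: a 1.5-fold higher number from compound 2 to compound 3 (0.18 log units; within the scatter).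

Compound 4 `CCOC(=O)[C@@H]1CCCN1c1c(C(=O)NCc2ccc(F)cc2F)c(=O)n(O)c2ncccc12` has not yet been measured in this assay. It differs from compound 1 by 2-(ethoxycarbonyl)pyrrolidin-1-yl in place of dimethylamino on an aromatic carbon. Both measured exchanges at this carbon bear on the step, and each moved the number up beyond the scatter while the two new groups sat within the scatter of each other. A step in the same direction, of comparable size, is therefore expected in this assay. Compound 4 is thus expected to give 45000 nM, with a range from 15000 nM to 120000 nM. In step terms this estimate means a 3.5-fold higher number from compound 1 to compound 4 (0.54 log units; beyond the scatter).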

Compound 4, half-maximal cytotoxic concentration: 18000 nM
Estimate against measurement, compound 4: 2.5-fold (0.40 log units) above; the measured number falls inside the stated range.
By their numbers in this assay, from the lowest: compounds 1 and 4 (each within the scatter of the next); then compounds 2 and 3 (each within the scatter of the next).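

In this assay, replacing dimethylamino at this aromatic carbon does not by itself move the number beyond the scatter: a 1.4-fold higher number from compound 1 to compound 4 (0.14 log units; within the scatter), unlike the two earlier exchanges. The choice of replacement group therefore matters here, since 2-(ethoxycarbonyl)pyrrolidin-1-yl stands apart from both earlier replacements: a 5.7-fold lower number from compound 3 to compound 4 (0.75 log units; beyond the scatter), and a 3.8-fold lower number from compound 2 to compound 4 (0.58 log units; beyond the scatter). Across the four compounds, the higher numbers go with the two amino groups that keep a hydrogen on the attached nitrogen, with no compound against this, but no measurement available explains it.

The compounds shown do not tell whether that hydrogen, the five-membered ring or the ethoxycarbonyl group accounts for the gap. Plain pyrrolidin-1-yl, the matching carboxylic acid and cycloheptylamino with a methyl on its nitrogen would each test one of these readings.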